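A few compounds are considered here, and "the series" means these few. Any claim that something is new, unique, unknown or untested is made for them only; others in the source may bear on it.

Measured in a functional assay on A2780 cells (Homo sapiens) for inhibition; a lower number here means a stronger inhibitor, a higher number a weaker inhibitor:
- Compound 1 `CCNC(=O)c1noc(-c2cc(C(C)C)c(O)cc2O)c1-c1cc(CNC(C)C)no1`: 38 nM
- Compound 2 `CCNC(=O)c1noc(-c2cc(C(C)C)c(O)cc2O)c1-c1cc(CN(C)C)no1`: 31 nM
- Compound 3 `CCNC(=O)c1noc(-c2cc(C(C)C)c(O)cc2O)c1-c1cc(CN2CCCC2)no1`: 55 nM

Compound 3 stands within the scatter of both other compounds: a 1.4-fold higher number from compound 1 to compound 3 (0.16 log units; within the scatter) and a 1.8-fold higher number from compound 2 to compound 3 (0.25 log units; within the scatter). Compound 4 `CCNC(=O)c1noc(-c2cc(C(C)C)c(O)cc2O)c1-c1cc(C(=O)OCC)no1` carries ethoxycarbonyl in place of (pyrrolidin-1-yl)methyl on an aromatic carbon. The measured steps, a 1.2-fold lower number from compound 1 to compound 2 (0.09 log units; within the scatter) among them, only exchange one amino group for another on a saturated chain carbon. None of them covers this change, so the data offer no direct guide to it. With nothing pointing either way, no step beyond the scatter is expected in this assay, though this expectation is uncertain. The expected move is a 1.1-fold higher number from compound 3 to compound 4 (0.04 log units; within the scatter). Compound 4 is estimated at 60 nM, with an expected range of 15 nM to 240 nM.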

Compound 4, half-maximal inhibitory concentration: 9000 nM
Compound 4: the middle estimate sits 150-fold (2.18 log units) below what was measured; measured number outside the range, above it.
By their numbers in this assay, from the lowest: compounds 2, 1 and 3 (each within the scatter of the next); then compound 4.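

In this assay the aromatic carbon that bears the amine-carrying chain proves far from indifferent to what it holds. The three amino groups on the saturated chain carbon stayed within the scatter of one another, but ethoxycarbonyl brings a 160-fold higher number from compound 3 to compound 4 (2.21 log units; beyond the scatter) as well as a 290-fold higher number from compound 2 to compound 4 (2.46 log units; beyond the scatter) and a 240-fold higher number from compound 1 to compound 4 (2.37 log units; beyond the scatter) and so sets compound 4 clearly apart from compounds 1, 2 and 3. Nothing available here explains a step of this size. The compounds shown leave open whether a carboxylic acid or a primary amide at this place would stand with compound 4 or with the amines. They also leave open how an amine on a longer chain would compare.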